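The source may hold more compounds than are shown below. What is called first, only, known or untested is meant among the compounds shown, and "the series" means these compounds.

Measured compounds:
compound 1 `Cn1c(=O)c(S(=O)(=O)c2ccc([N+](=O)[O-])cc2F)cc2cnc(Nc3ccc4[nH]ccc4c3)nc21` gives 400 nM
compound 2 `Cn1c(=O)c(S(=O)(=O)c2ccc(OC(=O)CCCCC3SCC4NC(=O)NC43)cc2)cc2cnc(Nc3ccc4[nH]ccc4c3)nc21` gives 150 nM
compound 3 `Cn1c(=O)c(S(=O)(=O)c2ccc(F)cc2F)cc2cnc(Nc3ccc4sccc4c3)nc21` gives 500 nM

All three numbers come from a functional assay on DU-145 cells (Homo sapiens) for inhibition, read by trypan blue exclusion, with a stated time of 72 h; a lower number here means a stronger inhibitor, a higher number a weaker inhibitor. Compound 1 stands second highest of the three; compound 3 lies within the scatter of it, while compound 2 sits beyond the scatter at the lower number. Within the data shown here, no single-point step between measured compounds is available.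

Compound 4 `Cn1c(=O)c(S(=O)(=O)c2ccc(N)cc2F)cc2cnc(Nc3ccc4[nH]ccc4c3)nc21` is the next case. It differs from compound 1 by amino in place of nitro on an aromatic carbon. Among the measured compounds shown here, no measured pair shows the effect of this change, so no direction can be read from the series; the expectation is a step of no size beyond the scatter, with the number of compound 4 estimated near that of compound 1. The step from compound 1 to compound 4 is expected to be a 1.3-fold higher number from compound 1 to compound 4 (0.10 log units; within the scatter). Compound 4 is therefore estimated at 500 nM, within 150 nM to 1600 nM.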

Compound 4, half-maximal inhibitory concentration: 8000 nM
Estimate against measurement, compound 4: 16-fold (1.20 log units) below, and the stated range ends below it.
By their numbers in this assay, from the lowest: compound 2; then compounds 1 and 3 (each within the scatter of the next); then compound 4.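

In this assay, among these compounds, amino in place of nitro gives a 20-fold higher number from compound 1 to compound 4 (1.30 log units; beyond the scatter), the only single-point step. The aromatic carbon para to a large group is therefore not indifferent to what it carries: exchanging this one group, 2-fluoro-4-nitrophenyl to 4-amino-2-fluorophenyl, moves the number well beyond the scatter. No measurement at hand bears on the origin of this step.

Open, as far as these compounds go, is how an acetamide, a methoxy group or a nitrile on this carbon would stand against nitro and amino. Also open, from the compounds shown here alone, is whether the step holds without the fluoro group.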